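Spiro-fused triazolylmethyl oxindoles tested against breast cancer cells

This account rests on a few compounds, and the source may have more. Where it says the series, first, only, none or still open, it means among the compounds named here.

The series is measured in a functional assay on MCF7 cells (Homo sapiens) for antiproliferative activity, read by MTT assay, with a stated time of 48 h; a higher number here means a weaker inhibitor, a lower number a stronger inhibitor. Compound 1 `N#CC1=C(N)Oc2c(c3nc4ccccc4nc3c3ccccc23)C12C(=O)N(Cc1cnnn1-c1ccc(F)c(Cl)c1)c1ccccc12` reaches only the limit of the assay, giving > 50000 nM. Compound 2 `N#CC1=C(N)Oc2c(c3nc4ccccc4nc3c3ccccc23)C12C(=O)N(Cc1cnnn1-c1ccc(Cl)c(Cl)c1)c1ccccc12` likewise returns a limit, > 50000 nM. The change between them, (chloro in place of fluoro on an aromatic carbon), therefore yields a step that the two limits leave unreadable from compound 1 to compound 2. Compound 3 `N#CC1=C(N)Oc2c(N)cc3nc4ccccc4nc3c2C12C(=O)N(Cc1cnnn1-c1ccc(F)cc1)c1ccccc12` carries a different core, and the difference between the two cores is not broken down here; in this assay compound 3 also stops at a limit, > 50000 nM. All three values thus share (the limit of > 50000 nM in this assay, at which 3 of the 3 values shown sit).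

Compound 4 `N#CC1=C(N)Oc2c(N)cc3nc4ccccc4nc3c2C12C(=O)N(Cc1cnnn1-c1ccc(Cl)cc1)c1ccccc12` is not yet measured. It is related to compound 3 by chloro in place of fluoro on an aromatic carbon, the same kind of change as that from compound 1 to compound 2, though here the place is para to a large group without being ortho to a chloro group. Because every measured member sits at the limit of > 50000 nM in this assay, at which 3 of the 3 values shown sit, the step from compound 3 to compound 4 is expected to be a step that the limit leaves unreadable from compound 3 to compound 4. Compound 4 is accordingly estimated at 60000 nM, most likely again reported only as a limit, within 20000 nM to 200000 nM.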

Compound 4, half-maximal inhibitory concentration: > 50000 nM
Compound 4 was reported as a limit; the forecaster's own chance of this, stated with the estimate: 85%; the middle value is on the limit's open side.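

Compound 3 and compound 4 are both reported only as limits in this assay, so no step can be read for chloro in place of fluoro between them: (the limit of > 50000 nM in this assay, at which 4 of the 4 values shown sit). The compounds shown leave open how they rank against one another and whether any change in this series gives a measurable value.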